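A few compounds are considered here, and "the series" means these few. Any claim that something is new, unique, unknown or untested is made for them only; others in the source may bear on it.

Measured compounds:
- compound 1 `N#Cc1cnc(NCc2cnccc2C(F)(F)F)cc1NC[C@H]1C[C@@H](O)C1`: in an ADME assay on S9 fraction from liver (Rattus norvegicus) for metabolic stability, with a stated time of 1 h (on this read-out higher numbers stand for a more stable compound and lower numbers for a less stable compound), compound 1 gives 44%
- compound 2 `N#Cc1cnc(NCc2cnccc2C(F)(F)F)cc1N[C@H]1CC[C@@H](O)CC1`: in this assay compound 2 gives 6%
- compound 3 `N#Cc1cnc(NCc2cnccc2C(F)(F)F)cc1NC1CCOCC1`: in this assay compound 3 gives 17%

Compound 1 stands highest of the three. Its nearest neighbour is compound 3, with a number 27 percentage points lower from compound 1 to compound 3 (beyond the scatter); compound 2 lies furthest, with a number 38 percentage points lower from compound 1 to compound 2 (beyond the scatter). Between the two lower compounds the gap is a number 11 percentage points higher from compound 2 to compound 3 (beyond the scatter).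

Compound 4 `CNC(=O)[C@H]1CC[C@@H](Nc2cc(NCc3cnccc3C(F)(F)F)ncc2C#N)CC1` is not yet measured. It differs from compound 1 in one place: 4-(methylcarbamoyl)cyclohexyl in place of (3-hydroxycyclobutyl)methyl on a nitrogen on an aromatic ring. The group that enters carries a six-membered carbon ring directly on the nitrogen, as compound 2 does; that exchange on the same nitrogen gave a number 38 percentage points lower from compound 1 to compound 2 (beyond the scatter). The oxan-4-yl exchange in compound 3 gave a number 27 percentage points lower from compound 1 to compound 3 (beyond the scatter). Both measured steps away from the (3-hydroxycyclobutyl)methyl group move downward beyond the scatter, so a downward step in this assay is expected for compound 4 as well. For the measured compounds named here, no measured step addresses the methylcarbamoyl group itself, so its exact weight is unknown and the range is kept wide. The expected step is a number 30 percentage points lower from compound 1 to compound 4 (beyond the scatter). Compound 4 is estimated at 14% in this assay, with a range from 4% to 30%.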

Compound 4, percent of the compound remaining: 53%
Compound 4: middle estimate off by 39 percentage points, on the low side; the measured number lies above the stated range.
By their numbers in this assay, from the lowest: compound 2; then compound 3; then compounds 1 and 4 (each within the scatter of the next).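

At this nitrogen on an aromatic ring, a six-membered carbon ring directly on the nitrogen does not by itself go with a low number in this assay: with that ring kept, a number 47 percentage points higher from compound 2 to compound 4 (beyond the scatter), the change being methylcarbamoyl in place of hydroxy on a saturated ring carbon. The 4-(methylcarbamoyl)cyclohexyl group also stands apart from oxan-4-yl, with a number 36 percentage points higher from compound 3 to compound 4 (beyond the scatter), whereas against (3-hydroxycyclobutyl)methyl the step is a number 9 percentage points higher from compound 1 to compound 4 (within the scatter), so compound 1 and compound 4 cannot be ordered in this read-out. Within these compounds, therefore, what the six-membered ring carries matters at least as much as the ring itself, and the larger group that enters in compound 4 shows no loss against compound 1.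

The compounds shown leave open which part of the methylcarbamoyl group goes with the higher number, a question that a primary carboxamide, a dimethylcarboxamide or a carboxylic acid on the same ring carbon could address. No measurement here bears on why the methylcarbamoyl and hydroxy groups differ so widely in this assay.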